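Working notes: acetyl for methyl on the aromatic nitrogen

This account rests on a few compounds, and the source may have more. Where it says the series, first, only, none or still open, it means among the compounds named here.

The set shares one core. Compound 1 `CCOC(=O)c1cnc(-c2ccccc2)nc1NN1C(=O)C=C(C)C1=O` is the parent; in a functional assay on Jurkat cells for inhibition of nuclear factor NF-kappa-B complex (Homo sapiens) (a higher number here means a weaker inhibitor, a lower number a stronger inhibitor), compound 1 gives 100 nM. Compound 2 `CCOC(=O)c1cnc(-c2ccc(F)cc2)nc1NN1C(=O)C=C(C)C1=O` carries fluoro in place of hydrogen on an aromatic carbon, and in this assay compound 2 gives 700 nM, a modest weakening (a 7.0-fold higher number from compound 1 to compound 2 (0.85 log units; beyond the scatter)). Compound 3 `CCOC(=O)c1cnc(-c2ccccc2)nc1N(C)N1C(=O)C=C(C)C1=O` carries methyl in place of hydrogen on a nitrogen on an aromatic ring, and in this assay compound 3 gives 2000 nM, the highest number of the three, beyond the scatter from compound 2 and further still from compound 1.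

Compound 4 `CCOC(=O)c1cnc(-c2ccccc2)nc1N(C(C)=O)N1C(=O)C=C(C)C1=O` differs from compound 3 by acetyl in place of methyl on a nitrogen on an aromatic ring. Within the data shown here, no measured pair compares two substituents on that nitrogen. Among the measured compounds shown here, the only step that bears on the place is the large one from hydrogen to methyl there (a 20-fold higher number from compound 1 to compound 3 (1.30 log units; beyond the scatter)). Compound 4 is expected to stay weak, with a small upward step (a 1.5-fold higher number from compound 3 to compound 4 (0.18 log units; within the scatter)) because a 20-fold higher number from compound 1 to compound 3 (1.30 log units; beyond the scatter) already sits far from compound 1 and the nitrogen remains substituted. Compound 4 is estimated at 3000 nM in this assay, range 1000 nM to 10000 nM.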

Compound 4, half-maximal inhibitory concentration: 4000 nM
Beside the measured number, compound 4's estimate is 1.3-fold (0.12 log units) below it; low and high end bracket the measured number.
By their numbers in this assay, from the lowest: compound 1; then compound 2; then compounds 3 and 4 (each within the scatter of the next).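

In this assay, among these compounds, compound 3 and compound 4 give the first comparison of two substituents on this nitrogen, and methyl and acetyl are not separated there (a 2.0-fold higher number from compound 3 to compound 4 (0.30 log units; within the scatter)). Set against the hydrogen of compound 1, acetyl also lands far off (a 40-fold higher number from compound 1 to compound 4 (1.60 log units; beyond the scatter)), so across compounds 1, 3 and 4 the large step goes with replacing the hydrogen, whichever of the two groups enters, even though acetyl adds heavy atoms and a hydrogen-bond acceptor. Nothing on hand gives a reason for these numbers.

From the compounds shown here alone, it remains open whether any other group on this nitrogen, such as ethyl, a longer chain, or a chain ending in an amine or a carboxylic acid, stays as far from compound 1. Also open, going by these compounds, is how the fluoro change seen in compound 2 behaves when acetyl or methyl sits on the nitrogen.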